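The source may hold more compounds than are shown below. What is called first, only, known or untested is meant among the compounds shown, and "the series" means these compounds.

Of the compounds shown here, three that share one core have been measured in a functional assay on CHO cells with adenosine receptor A1 (Homo sapiens) as the target, read by cAMP accumulation and immunoassay, with a stated time of 6 min, tested at 0.1 uM; on this read-out lower numbers stand for a stronger effect and higher numbers for a weaker effect at the one concentration tested. Compound 1 `Nc1scc(CN2CCN(c3cccc(C(F)(F)F)c3)CC2)c1C(=O)c1ccc(Cl)cc1` gives -30%, compound 2 `Nc1scc(CN2CCN(c3ccc(OC(F)(F)F)cc3)CC2)c1C(=O)c1ccc(Cl)cc1` gives -13%, and compound 3 `Nc1scc(CN2CCN(c3ccncc3)CC2)c1C(=O)c1ccc(Cl)cc1` gives 1.4%, the highest of the three numbers, with compound 2 nearest and compound 1 furthest. Compound 4 `Nc1scc(CN2CCN(c3c(F)cc(F)cc3F)CC2)c1C(=O)c1ccc(Cl)cc1` has not been measured yet. Its change from compound 3 is 2,4,6-trifluorophenyl in place of pyridin-4-yl on an amine nitrogen in a ring. For the measured compounds named here, the steps that bear on this are those from a 3-(trifluoromethyl)phenyl or a 4-(trifluoromethoxy)phenyl to the pyridin-4-yl group, a number 31.4 percentage points higher from compound 1 to compound 3 (beyond the scatter) and a number 14.4 percentage points higher from compound 2 to compound 3 (beyond the scatter). Going back from pyridin-4-yl to a phenyl ring in this assay, a lower number is therefore expected, roughly a number 16.4 percentage points lower from compound 3 to compound 4 (beyond the scatter). Compound 4 is estimated at -15%, between -35% and 5%.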

Compound 4, a percentage reported as activity, at one concentration (the size of the read-out at that concentration, not a potency): -3.9%
Compound 4: the middle estimate sits 11.1 percentage points below what was measured, within the range that was stated.
By their numbers in this assay, from the lowest: compound 1; then compounds 2, 4 and 3 (each within the scatter of the next, the first and the last beyond it).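

On an amine nitrogen in a ring, 2,4,6-trifluorophenyl cannot be told apart in this assay from pyridin-4-yl (a number 5.3 percentage points lower from compound 3 to compound 4 (within the scatter)) or from 4-(trifluoromethoxy)phenyl (a number 9.1 percentage points higher from compound 2 to compound 4 (within the scatter)), while 3-(trifluoromethyl)phenyl stands clearly apart (a number 26.1 percentage points higher from compound 1 to compound 4 (beyond the scatter)). A ring of carbon only is therefore not enough to reach the number of compound 1, as compound 2 and compound 4 both show. Nothing measured here gives a reason for this. The compounds shown leave open whether a phenyl ring carrying a single fluorine, an amine or a carboxylic acid would fall nearer compound 1 or compound 3.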